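From 4-chlorophenyl to 2,5-dihydroxyphenyl on a shared core

This account rests on a few compounds, and the source may have more. Where it says the series, first, only, none or still open, it means among the compounds named here.

Of the compounds shown here, three with a shared core have been measured in a functional assay on SW982 cells (Homo sapiens) for inhibition, read by MTT assay, with a stated time of 72 h; on this read-out lower numbers stand for stronger inhibition and higher numbers for weaker inhibition. In this set, compound 1 `COc1cc(OC)c(OC)cc1/C=C/C(=O)c1ccc(Cl)cc1` gives 58500 nM. Compound 2 `COc1cc(OC)c(OC)cc1/C=C/C(=O)c1cc(Cc2ccccc2)cc(Cc2ccccc2)c1` gives 69900 nM, which lies within the scatter of the value for compound 1. Compound 3 `COc1cc(OC)c(OC)cc1/C=C/C(=O)c1ccc(Cl)c([N+](=O)[O-])c1` gives 20600 nM. Compound 1 therefore stands level with compound 2 and apart from compound 3, at the higher end of the numbers.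

Compound 4 `COc1cc(OC)c(OC)cc1/C=C/C(=O)c1cc(O)ccc1O` has not yet been measured. It differs from compound 1 at a single place, with 2,5-dihydroxyphenyl in place of 4-chlorophenyl on a carbonyl carbon.

For the measured compounds named here, only one measured step bears on this change, and it does so indirectly. Nitro in place of hydrogen on an aromatic carbon of the 4-chlorophenyl ring gives a 2.8-fold lower number from compound 1 to compound 3 (0.45 log units; beyond the scatter), a modest step. Going by the values given here, that step keeps the chlorine, and no measured compound carries a hydroxyl group, so the data offer no direct precedent for compound 4. A modest move to a lower number is expected, although a result close to compound 1 would be no surprise. The expected step is a 2.1-fold lower number from compound 1 to compound 4 (0.32 log units; beyond the scatter). For compound 4 the estimated value is 28000 nM, with an expected range from 9000 nM to 70000 nM.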

Compound 4, half-maximal inhibitory concentration: > 150000 nM
Compound 4 was reported as a limit; the forecaster's own chance of this, stated with the estimate: 10%; middle value at least 5.3-fold (0.72 log units) away from the limit.
By their numbers in this assay, from the lowest: compound 3; then compounds 1 and 2 (each within the scatter of the next). At a limit, above all of these: compound 4.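

In this assay, 2,5-dihydroxyphenyl in place of 4-chlorophenyl on a carbonyl carbon gives an at least 2.5-fold higher number from compound 1 to compound 4 (0.40 log units; beyond the scatter), the only step shown that goes to a higher number beyond the scatter. The value for compound 4 is a limit: the limit of > 150000 nM in this assay, at which 1 of the 4 values shown sits. Set against a 2.8-fold lower number from compound 1 to compound 3 (0.45 log units; beyond the scatter), a change that keeps the chlorine, this shows that changes to the aromatic ring on the carbonyl carbon can move the number in either direction, and that the entering group here, the only one shown with hydrogen-bond donors, goes with the higher number rather than the lower one.

The compounds shown leave open whether the step follows the loss of the chlorine or the arrival of the hydroxyl groups, since both change together in compound 4. They also leave open how this ring would read in this assay if it carried an amine or a carboxylic acid, and so whether the higher number is tied to hydroxyl groups in particular or extends to other groups at this place.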